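Shrinking the Ring Carried by the Core Nitrogen

A few compounds are considered here, and "the series" means these few. Any claim that something is new, unique, unknown or untested is made for them only; others in the source may bear on it.

Three compounds have been measured in an ADME assay on microsomes from liver (Homo sapiens) for metabolic stability, tested at 2.5 uM; on this read-out higher numbers stand for fast clearance and lower numbers for slow clearance:

Compound 1 `Fc1cccc(Cn2nnc3c(Br)cccc32)c1`: 1.8 mL/min/g
Compound 2 `Brc1cccc2c1nnn2CC1CCCC1`: 7.9 mL/min/g
Compound 3 `Brc1cccc2c1nnn2CC1CCC1`: 8.7 mL/min/g

Compound 3 sits at the top end of these three numbers, side by side with compound 2, whose value lies within the scatter of it, and well apart from compound 1, whose value lies beyond the scatter.

Compound 4 `Brc1cccc2c1nnn2CC1CC1` differs from compound 3 in one place: cyclopropyl in place of cyclobutyl on a saturated chain carbon bound to an aromatic nitrogen. The same kind of change, one ring size larger, has already been seen: a 1.1-fold higher number from compound 2 to compound 3 (0.04 log units; within the scatter). That step showed nothing beyond the scatter, so the further shrinking of the ring from cyclobutyl to cyclopropyl is expected to leave the number near where compound 3 stands, and the step of a 1.0-fold lower number from compound 3 to compound 4 (0.01 log units; within the scatter) is estimated to fall within the scatter. Compound 4 is therefore expected to give about 8.5 mL/min/g in this assay, with a likely range from 4.5 mL/min/g to 16 mL/min/g.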

Compound 4, intrinsic clearance in a liver preparation (reported as CLH), per the amount of preparation that the assay uses: 1.3 mL/min/g
The estimate for compound 4 lay 6.5-fold (0.82 log units) above the measured number; the measured number lies below the stated range.
By their numbers in this assay, from the lowest: compounds 4 and 1 (each within the scatter of the next); then compounds 2 and 3 (each within the scatter of the next).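

At this position, on a saturated chain carbon bound to an aromatic nitrogen, ring size does matter in this assay: the change to cyclopropyl gives a 6.7-fold lower number from compound 3 to compound 4 (0.83 log units; beyond the scatter) and also a 6.1-fold lower number from compound 2 to compound 4 (0.78 log units; beyond the scatter) even though the cyclobutyl and cyclopentyl compounds lie within the scatter of each other. For the compounds shown here, the response to ring size is therefore uneven, with the only step beyond the scatter coming when the four-membered ring gives way to the three-membered one. No measurement here explains this sharp change.

From the compounds shown here alone, it remains open whether the low number is particular to the three-membered ring or would also appear with a short open chain such as isopropyl. Going by these compounds, how a ring carrying an amine would behave at this position also remains open.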